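Three arylamino analogues of one shared core

The source may hold more compounds than are shown below. What is called first, only, known or untested is meant among the compounds shown, and "the series" means these compounds.

The series has three compounds that share one core and differ only in the aryl group on the ring nitrogen. Compound 1, `COc1ccc(-c2c(Nc3ccc(F)cc3)c3ccccc3oc2=O)cc1`, carries a 4-fluorophenyl there; in a functional assay on PANC-1 cells (Homo sapiens) for antiproliferative activity, read by MTT assay, with a stated time of 48 h (a higher number here means a weaker inhibitor, a lower number a stronger inhibitor), compound 1 gives 32000 nM. Compound 2, `COc1ccc(-c2c(Nc3ccc(NC(C)=O)cc3)c3ccccc3oc2=O)cc1`, carries a 4-acetamidophenyl in its place, and in this assay compound 2 gives "not determined" (no result reported), so no number exists for compound 2 and its standing cannot be stated. Compound 3, `COc1ccc(-c2c(Nc3cccc(C(F)(F)F)c3)c3ccccc3oc2=O)cc1`, has not yet been measured. It differs from compound 2 by 3-(trifluoromethyl)phenyl in place of 4-acetamidophenyl on a nitrogen on an aromatic ring. Within the data shown here, since compound 2 has no value, no step between the two can be computed, and the only anchor is compound 1. On that basis compound 3 is expected to land somewhere near compound 1 in this assay, with no clear direction of change and a step that would likely stay within the scatter of a single value. Compound 3 is therefore estimated at 30000 nM, with a range from 8000 nM to 100000 nM.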

Compound 3, half-maximal inhibitory concentration: 49100 nM
The estimate for compound 3 lay 1.6-fold (0.21 log units) below the measured number; low and high end bracket the measured number.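

In this assay, the step to 3-(trifluoromethyl)phenyl in place of 4-fluorophenyl on a nitrogen on an aromatic ring is a 1.5-fold higher number from compound 1 to compound 3 (0.19 log units; within the scatter), so this position now holds two aryl groups with measured values, and this read-out does not tell them apart. The step from compound 2 to compound 3 cannot be read, so the 4-acetamidophenyl group adds nothing to what is known about this position, and the comparison rests on compound 1 and compound 3 alone. No independent evidence accompanies this result to account for it.

The step from compound 1 to compound 3 changes both the substituent and its numbered place on the phenyl ring, so the compounds shown leave open whether either change alone would have any effect on the number. They also leave open whether an amine or a carboxylic acid on that phenyl ring, or a butyl chain on the nitrogen in place of the aryl group, would move the value beyond the scatter.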